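Methyl in place of hydrogen on a flavanonol phenol

The source may hold more compounds than are shown below. What is called first, only, known or untested is meant among the compounds shown, and "the series" means these compounds.

Measured compounds:
compound 1 `COc1cc2c(c(OC)c1O)C(=O)[C@H](O)[C@@H](c1ccc(O)cc1)O2`: -3.8%
compound 2 `COc1ccc([C@@H]2Oc3cc(OC)c(O)c(OC)c3C(=O)[C@@H]2O)cc1OC`: 2.9%

Two compounds have numbers in a functional assay on PC-12 cells (Rattus norvegicus) for cytotoxicity, read by MTT assay, with stated times of 2 h and 4 h, tested at 8 ug/mL; a lower number here means a weaker effect, a higher number a stronger effect of the compound at the concentration tested. Compound 1 `COc1cc2c(c(OC)c1O)C(=O)[C@H](O)[C@@H](c1ccc(O)cc1)O2` gives -3.8% there, and compound 2 `COc1ccc([C@@H]2Oc3cc(OC)c(O)c(OC)c3C(=O)[C@@H]2O)cc1OC` gives 2.9%. The gap between these two values lies within the usual scatter of repeated measurements, so neither compound stands apart from the other, and both read as essentially no effect at the concentration tested.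

Compound 3 `COc1cc2c(c(OC)c1OC)C(=O)[C@H](O)[C@@H](c1ccc(O)cc1)O2` is not yet measured in this assay. It differs from compound 1 by a single change: methyl in place of hydrogen on an oxygen on an aromatic ring. Going by the values given here, no step between measured compounds covers this change, so the expectation rests on the two values alone.

With compound 1 and compound 2 both near zero, compound 3 is expected to remain there as well, with an estimated step of a number 3.8 percentage points higher from compound 1 to compound 3 (within the scatter) that stays within the scatter. The estimate for compound 3 in this assay is 0%, ranging from -12% to 12%.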

Compound 3, a percentage reported as activity, at one concentration (the size of the read-out at that concentration, not a potency): -1.4%
Beside the measured number, compound 3's estimate is 1.4 percentage points above it; low and high end bracket the measured number.
By their numbers in this assay, from the lowest: compounds 1, 3 and 2 (each within the scatter of the next).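

In this assay, going by these compounds alone, the change from hydroxy to methoxy on the shared core amounts to a number 2.4 percentage points higher from compound 1 to compound 3 (within the scatter) and gives the first reading of a single change on this oxygen. Methyl in place of hydrogen at this place does not separate the two compounds, and both read as essentially no effect at the concentration tested, so this pair links the position to no change in the read-out. No independent evidence bears on this result.

On these data alone, whether a group other than methyl on this oxygen, such as a longer chain or one ending in an amine or a carboxylic acid, would read differently stays open. The compounds shown all lie near zero, so it is also open whether this change would matter on a compound with a clear effect.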